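The source may report more compounds than this note shows. Statements on the series, on what has been measured and on what is new or still open speak of the compounds shown alone.

In a functional assay on LNCaP cells (Homo sapiens) for antiproliferative activity, read by fluorescence and propidium iodide staining, with a stated time of 96 h (a higher number here means a weaker inhibitor, a lower number a stronger inhibitor), compound 3 `CC(O)(COc1cc(C(F)(F)F)cc(C(F)(F)F)c1)C(=O)Nc1ccc(C#N)cc1C(F)(F)F` gives 3560 nM. Compound 1 `CC(O)(CSc1ccccc1OC(F)(F)F)C(=O)Nc1cc(C(F)(F)F)cc(C(F)(F)F)c1` gives 2910 nM and compound 2 `CC(O)(COc1cc(C(C)(C)C)cc(C(C)(C)C)c1)C(=O)Nc1ccc(C#N)c(C(F)(F)F)c1` gives 2670 nM. The value of compound 3 lies within the scatter of both other values, so this assay does not separate the three compounds. Compound 4 `CC(O)(COc1cc(C(F)(F)F)cc(C(F)(F)F)c1)C(=O)Nc1ccc([N+](=O)[O-])cc1C(F)(F)F` is not yet measured. It differs from compound 3 by nitro in place of cyano on an aromatic carbon, meta to a trifluoromethyl group and para to a large group. For the measured compounds named here, no measured pair in this set shows that exchange, so the size of the step rests on expectation alone. No shift beyond the scatter is expected, a step of a 1.0-fold lower number from compound 3 to compound 4 (0.01 log units; within the scatter) being the estimate. For compound 4 a value of 3500 nM is expected, in the range 1500 nM to 8000 nM.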

Compound 4, half-maximal inhibitory concentration: 24000 nM
Beside the measured number, compound 4's estimate is 6.9-fold (0.84 log units) below it; measured number above the stated range.
By their numbers in this assay, from the lowest: compounds 2, 1 and 3 (each within the scatter of the next); then compound 4.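

In this assay, the aromatic carbon meta to a trifluoromethyl group and para to a large group is sensitive to its substituent: nitro in place of cyano gives a 6.7-fold higher number from compound 3 to compound 4 (0.83 log units; beyond the scatter). For the compounds shown here, this is the first step in the set that lies beyond the scatter, and it rests on a single pair. Nothing available bears on what lies behind it.

As far as these compounds go, whether the exchange keeps this size on another background remains open. So does how an amine, a carboxylic acid or a chlorine at this carbon would read in this assay.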